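Predicting Half-Life of a Methoxy Analogue of Compound 1

The source may report more compounds than this note shows. Statements on the series, on what has been measured and on what is new or still open speak of the compounds shown alone.

Measured compounds:
compound 1, `O=C(Sc1cccnc1C(=O)O)c1ccccc1`: 60.1 h
compound 2, `O=C(Sc1cccnc1C(=O)O)c1ccc(C(F)(F)F)cc1`: 10.1 h

Among the measured compounds shown here, in a physicochemical assay for pharmacokinetics, at pH 8 (on this read-out lower numbers stand for a shorter-lived compound and higher numbers for a longer-lived compound), compound 1 stands highest of the two numbers, and the only measured step is a 6.0-fold lower number from compound 1 to compound 2 (0.77 log units; beyond the scatter). Compound 3, `COc1cccc(C(=O)Sc2cccnc2C(=O)O)c1`, differs from compound 1 by methoxy in place of hydrogen on an aromatic carbon. For the measured compounds named here, the single measured step concerns a different group at a different place, so it bears only loosely on this change, and nothing shows how a methoxy behaves here. Compound 3 is therefore expected to give a smaller step, a 1.5-fold lower number from compound 1 to compound 3 (0.18 log units; within the scatter), with an estimate of 40 h ranging from 15 h to 90 h.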

Compound 3, half-life: 63.7 h
Compound 3: the middle estimate sits 1.6-fold (0.20 log units) below what was measured; the measured number falls inside the stated range.
By their numbers in this assay, from the lowest: compound 2; then compounds 1 and 3 (each within the scatter of the next).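

In this assay, methoxy in place of hydrogen on an aromatic carbon, meta to a large group, gives a 1.1-fold higher number from compound 1 to compound 3 (0.03 log units; within the scatter), so this substitution leaves the half-life within the scatter of compound 1, a case the earlier trifluoromethyl step, which lay beyond the scatter, could not show. No available measurement accounts for this result. Going by these compounds, whether an amine or a carboxylic acid at this place would match methoxy remains open. So does whether trifluoromethyl, set at this same place, would behave as it did in compound 2.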